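The source may report more compounds than this note shows. Statements on the series, on what has been measured and on what is new or still open speak of the compounds shown alone.

Measured so far in a functional assay on A549 cells (Homo sapiens) for antiproliferative activity, read by MTT assay, with a stated time of 48 h; on this read-out lower numbers stand for stronger inhibition and higher numbers for weaker inhibition:
compound 1 `CCCCCCCCCCCCOc1ccc(C(=O)/C=C/c2c(/C=C/c3ccc(OC)cc3)cc(OC)cc2OC)cc1` 7.9 ug/mL
compound 2 `COc1ccc(/C=C/c2cc(OC)cc(OC)c2/C=C/C(=O)c2ccc(Cl)c(Cl)c2)cc1` 5.9 ug/mL
compound 3 `COc1ccc(/C=C/c2cc(OC)cc(OC)c2/C=C/C(=O)c2ccc(Br)cc2)cc1` 8.3 ug/mL

Compound 3 gives the largest of the three numbers, but its gaps to compound 1 and compound 2 both lie within the scatter; the three compounds are indistinguishable on this read-out.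

Compound 4 `COc1ccc(/C=C/c2cc(OC)cc(OC)c2/C=C/C(=O)c2ccc(OC)cc2)cc1` differs from compound 3 as follows: methoxy in place of bromo on an aromatic carbon. Within the data shown here, the only measured step, a 1.4-fold higher number from compound 2 to compound 3 (0.15 log units; within the scatter), exchanges one halogen pattern for another and is itself within the scatter. Among the measured compounds shown here, no measured step puts methoxy in place of a halogen here; compound 1, carrying a long alkoxy chain at that place, gives a number in the same range as compound 3. On that basis, no step beyond the scatter is expected, and compound 4 is estimated at 8 ug/mL (range 3.5 ug/mL to 18 ug/mL), a step of a 1.0-fold lower number from compound 3 to compound 4 (0.02 log units; within the scatter).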

Compound 4, half-maximal inhibitory concentration: 4.5 ug/mL
The estimate for compound 4 lay 1.8-fold (0.25 log units) above the measured number; the range from low to high includes it.
By their numbers in this assay, from the lowest: compounds 4, 2, 1 and 3 (each within the scatter of the next).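

On an aromatic carbon para to a large group, methoxy in place of bromo gives a 1.8-fold lower number from compound 3 to compound 4 (0.27 log units; within the scatter) in this assay, so a halogen is not required at this place for a number in this range. Taking 4-methoxyphenyl in place of 3,4-dichlorophenyl gives a 1.3-fold lower number from compound 2 to compound 4 (0.12 log units; within the scatter), and hydrogen in place of undecyl on the alkoxy chain gives a 1.8-fold lower number from compound 1 to compound 4 (0.24 log units; within the scatter), so all three changes stay within the scatter. No evidence on what lies behind these steps is available.

From the compounds shown here alone, whether an amine or a carboxylic acid at this place would give a step beyond the scatter remains open.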